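Working notes on the series: methoxy in place of iodo

The source may hold more compounds than are shown below. What is called first, only, known or untested is meant among the compounds shown, and "the series" means these compounds.

compound 1, `O=C(/C=C/c1ccc2c(c1)B(O)OC2)c1ccc(I)cc1`: > 10 ug/mL in an ADME assay on L929 cells (Mus musculus) for cytotoxicity, read by resazurin assay, with a stated time of 72 h; on this read-out higher numbers stand for weaker inhibition and lower numbers for stronger inhibition
compound 2, `COc1cccc(C(=O)/C=C/c2ccccc2)c1`: 5.7 ug/mL
compound 3, `O=C(/C=C/c1ccc2c(c1)B(O)OC2)c1ccco1`: > 10 ug/mL

The reading for compound 1 is a limit of the assay, not a number. The reading for compound 3 is likewise a limit. Compound 2 alone gives a number. Among the compounds with values here, compound 1 therefore stands only at a limit, and the one step that touches it, a step that the two limits leave unreadable from compound 1 to compound 3, cannot be read because of the limit of > 10 ug/mL in this assay, at which 2 of the 3 values shown sit. Compound 4, `COc1ccc(C(=O)/C=C/c2ccc3c(c2)B(O)OC3)cc1`, is not yet measured; it differs from compound 1 thus: methoxy in place of iodo on an aromatic carbon. Within the data shown here, no measured step sets a methoxy against an iodo on the shared core, so the step that the limit leaves unreadable from compound 1 to compound 4 is expected to stay within the scatter, though only as an estimate. Compound 4 is expected to give 12 ug/mL, between 5 ug/mL and 30 ug/mL.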

Compound 4, half-maximal inhibitory concentration: > 10 ug/mL
Compound 4 ended at the assay's limit (the forecaster's own chance of this, stated with the estimate: 65%); the middle value lies beyond the limit too.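

Compound 4 stands at a limit of the assay, as compound 1 does, so no step between compound 1 and compound 4 can be read: the limit of > 10 ug/mL in this assay, at which 3 of the 4 values shown sit.

The compounds shown leave open whether methoxy in place of iodo changes the result in this assay at all.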